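The compounds below may be only part of what the source reports. "The series", "measured", "known", "first", "only" and "open" are said of these compounds alone.

Measured compounds:
- compound 1 `ClCc1cccc(Cn2cnc3c(Cl)nc(Cl)nc32)c1` — 7760 nM
- compound 2 `ClCc1ccccc1Cn1cnc2ncnc(Cl)c21` — 10000 nM
- compound 3 `ClCc1ccc(Cn2cnc3c(Cl)nc(Cl)nc32)cc1` — 56200 nM

All three numbers come from a functional assay on SW-620 cells (Homo sapiens) for cytotoxicity, read by sulforhodamine B assay, with a stated time of 48 h; a lower number here means that less compound is tolerated, a higher number that more compound is tolerated. Within this set compound 2 stands second highest of three. Its nearest neighbour is compound 1, whose number is lower by an amount that stays within the scatter, so no order can be read from that pair. Its furthest neighbour is compound 3, whose number is higher by an amount beyond the scatter. Going by the values given here, no pair among the measured compounds differs in a single place, so no step of this kind has been measured here.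

Compound 4 `ClCc1ccccc1Cn1cnc2nc(Cl)nc(Cl)c21` is the next compound to be tested. It differs from compound 2 by chloro in place of hydrogen on an aromatic carbon. Among the compounds with values here, nothing among the measured compounds isolates such a change, and the two values within the scatter of each other, compound 1 and compound 2, give no lead either way. The step of no change at the digits printed from compound 2 to compound 4 (within the scatter) is therefore expected to stay within the scatter, with no clear direction. Compound 4 is estimated at 10000 nM, with a range from 3000 nM to 35000 nM in this assay.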

Compound 4, concentration lethal to 50% of the cells: 4670 nM
Beside the measured number, compound 4's estimate is 2.1-fold (0.33 log units) above it; low and high end bracket the measured number.
By their numbers in this assay, from the lowest: compounds 4, 1 and 2 (each within the scatter of the next, the first and the last beyond it); then compound 3.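

In this assay, going by these compounds alone, chloro in place of hydrogen on an aromatic carbon between two ring nitrogen atoms gives a 2.1-fold lower number from compound 2 to compound 4 (0.33 log units; beyond the scatter) and so provides the first single-place step. The step shows that this position is not silent to the change, with a lower number on gaining chloro, although its size is modest and it rests on this one pair. No measurement shown here gives a cause for this step.

Open, as far as these compounds go, is whether an amine, a methoxy group or a longer chain on the same carbon would shift the number in the same direction as chloro. Also open, from the compounds shown here alone, is whether the reverse change, hydrogen in place of this chloro, would give a step of like size from compound 1 or from compound 3.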